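A few compounds are considered here, and "the series" means these few. Any claim that something is new, unique, unknown or untested is made for them only; others in the source may bear on it.

Compound 1 `COc1cccc(C=C(C(=O)/C=C/c2cccc(OC)c2OC)C(=O)/C=C/c2cccc(OC)c2OC)c1OC`: 230 nM
Compound 2 `COc1ccc(OC)c(/C=C/C(=O)C(=Cc2ccc(OC)c(OC)c2)C(=O)/C=C/c2cc(OC)ccc2OC)c1`: 260 nM
Compound 3 `COc1ccc(OC)c(/C=C/C(=O)C(=Cc2ccc(O)c(F)c2)C(=O)/C=C/c2cc(OC)ccc2OC)c1`: 220 nM

These three values come from a functional assay on HepG2 cells (Homo sapiens) for antiproliferative activity, read by sulforhodamine B assay, with a stated time of 48 h; a lower number here means a stronger inhibitor, a higher number a weaker inhibitor. Compound 3 gives 220 nM, which lies within the usual scatter of the other two numbers, so the data do not rank it above or below either one.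

The next compound to consider is compound 4 `COc1ccc(OC)c(/C=C/C(=O)C(=Cc2ccc(OC)c(O)c2)C(=O)/C=C/c2cc(OC)ccc2OC)c1`. Its structural change from compound 3 is 3-hydroxy-4-methoxyphenyl in place of 3-fluoro-4-hydroxyphenyl on a double-bonded chain carbon bound to a double-bonded chain carbon. In words, 3-hydroxy-4-methoxyphenyl takes the place of 3-fluoro-4-hydroxyphenyl on a double-bonded chain carbon bound to a double-bonded chain carbon.

Among the measured compounds shown here, only one measured step changes the group at this place: a 1.2-fold lower number from compound 2 to compound 3 (0.07 log units; within the scatter). There, 3-fluoro-4-hydroxyphenyl replaced 3,4-dimethoxyphenyl, and the number in this assay barely moved beyond what repeat measurements would give. For the measured compounds named here, compound 1 is not linked to compound 3 by a single change, so it offers no direct step. Going by the values given here, no measured compound carries the 3-hydroxy-4-methoxyphenyl group, so this evidence is indirect and thin.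

With that one small step as the guide, no change beyond the scatter is expected, and the expected step is a 1.0-fold higher number from compound 3 to compound 4 (0.02 log units; within the scatter). The estimated value for compound 4 is 230 nM, with an expected range from 105 nM to 500 nM.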

Compound 4, half-maximal inhibitory concentration: 470 nM
Compound 4: the middle estimate sits 2.0-fold (0.31 log units) below what was measured; the measured number falls inside the stated range.
By their numbers in this assay, from the lowest: compounds 3, 1, 2 and 4 (each within the scatter of the next, the first and the last beyond it).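

In this assay, among the compounds shown here, the single earlier change at this place stayed within the scatter, so the group on this double-bonded chain carbon could have seemed to matter little, but 3-hydroxy-4-methoxyphenyl in place of 3-fluoro-4-hydroxyphenyl gives a 2.1-fold higher number from compound 3 to compound 4 (0.33 log units; beyond the scatter), a modest but real loss of strength. Hydrogen in place of methyl on an oxygen on an aromatic ring gives a 1.8-fold higher number from compound 2 to compound 4 (0.26 log units; within the scatter), which stays within the scatter, so that smaller edit cannot be called a loss on its own, and the group here is shown to matter only when compound 3 and compound 4 are set side by side. The compounds shown offer no measurement that would explain the step.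

As far as these compounds go, the step from compound 3 to compound 4 alters the fluorine, the hydroxyl and the methoxy together, so the share of each remains unknown. From the compounds shown here alone, it also remains open whether an amine or a carboxylic acid on this aromatic ring would hold the number close to that of compound 3, or whether the same change would have a similar effect on the core of compound 1.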